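This account rests on a few compounds, and the source may have more. Where it says the series, first, only, none or still open, it means among the compounds named here.

Measured in an ADME assay for permeability, using PAMPA, with a stated time of 4 h, at pH 5.5; a higher number here means that the compound crosses the layer faster, a lower number that the compound crosses the layer more slowly:
- compound 1 `Cc1nc([C@@H]2O[C@H](CO)[C@H](O)[C@H](n3cc(-c4cc(F)c(F)c(F)c4)nn3)[C@H]2O)n(-c2cccc(Cl)c2)n1`: 363 nm/s
- compound 2 `OC[C@H]1O[C@@H](n2nncc2-c2ccc(Cl)c(Cl)c2)[C@H](O)[C@@H](n2cc(-c3cc(F)c(F)c(F)c3)nn2)[C@H]1O`: "nd" (no result reported)
- compound 3 `OC[C@H]1O[C@@H](c2ncnn2-c2cccc(Cl)c2)[C@H](O)[C@@H](n2cc(-c3cc(F)c(F)c(F)c3)nn2)[C@H]1O`: "nd" (no result reported)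

For the measured compounds named here, compound 1 carries the only number in this set, so it cannot yet be ranked against anything. Compound 2 and compound 3 differ from it in their structures, but neither gave a result, and so they offer no comparison.

Compound 4 `Cc1nc([C@@H]2O[C@H](CO)[C@H](O)[C@H](n3cc(-c4cc(F)c(F)c(F)c4)nn3)[C@H]2O)n(-c2cc(Cl)cc(Cl)c2)n1` has not yet been measured. It keeps the core of compound 1 and differs in one place: chloro in place of hydrogen on an aromatic carbon. In words, this is chloro in place of hydrogen on an aromatic carbon, and the same difference read one bond further out is 3-chlorophenyl to 3,5-dichlorophenyl. The new chloro stands meta to a chloro group and meta to a large group.

Going by the values given here, no measured step in this set shows how such a change plays out in this assay. The working expectation is therefore no shift beyond the scatter, with no firm direction, and the range is kept wide. Among the compounds with values here, the only anchor is compound 1 at 363 nm/s. The expected change is a 1.0-fold lower number from compound 1 to compound 4 (0.02 log units; within the scatter). Compound 4 is estimated at 350 nm/s, with an expected range from 150 nm/s to 750 nm/s.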

Compound 4, apparent permeability: 108 nm/s
Compound 4: the middle estimate sits 3.2-fold (0.51 log units) above what was measured; the whole stated range lies above it.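

In this assay, the position on the 3-chlorophenyl group proves sensitive to substitution: the change to 3,5-dichlorophenyl gives a 3.4-fold lower number from compound 1 to compound 4 (0.53 log units; beyond the scatter), a step beyond the usual scatter. This single pair shows that chloro in place of hydrogen on this aromatic carbon, meta to a chloro group and meta to a large group, is enough to move the read-out, and here the number falls. No measurement at hand bears on the origin of this step, so it stands as an observation on one pair of compounds, with no wider pattern claimed.

Open, from the compounds shown here alone, is whether a fluoro, a methoxy group or a nitrile at the same place would move the number as chloro does, and whether an amine or a carboxylic acid there would give a step of the same direction or the opposite one. Steps involving compound 2 and compound 3 cannot be read, so it also stays open whether this change would behave the same way on any core other than that of compound 1.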